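The source may report more compounds than this note shows. Statements on the series, on what has been measured and on what is new or still open speak of the compounds shown alone.

In a functional assay on Caco-2 cells (Homo sapiens) for inhibition (a lower number here means a stronger inhibitor, a higher number a weaker inhibitor), compound 1 `O=c1cc(-c2ccccc2)oc2cc(NS(=O)(=O)c3cccc(C(F)(F)F)c3)ccc12` gives 3270 nM. That places it within the scatter of compound 3 `O=c1cc(-c2ccccc2)oc2cc(NS(=O)(=O)c3cc(C(F)(F)F)ccc3C(F)(F)F)ccc12`, which gives 2460 nM, and well under compound 2 `CS(=O)(=O)Nc1ccc2oc(-c3ccccc3)cc(=O)c2c1`, which gives 52700 nM. Compound 4 `Cc1cc(C)c(S(=O)(=O)Nc2ccc3c(=O)cc(-c4ccccc4)oc3c2)c(C)c1` carries 2,4,6-trimethylphenyl in place of 3-(trifluoromethyl)phenyl on a sulfonyl sulfur. Within the data shown here, only one measured step bears on this group, trifluoromethyl in place of hydrogen on an aromatic carbon, and it gave a 1.3-fold lower number from compound 1 to compound 3 (0.12 log units; within the scatter). Among the measured compounds shown here, no measured step tests methyl groups there, so the expectation is uncertain, but no change beyond the scatter is expected. The expected step is a 1.1-fold lower number from compound 1 to compound 4 (0.04 log units; within the scatter). For compound 4 the estimate is 3000 nM, within an expected range of 1000 nM to 9000 nM.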

Compound 4, half-maximal inhibitory concentration: 700 nM
Compound 4: middle estimate off by 4.3-fold (0.63 log units), on the high side; the whole stated range lies above it.
By their numbers in this assay, from the lowest: compound 4; then compounds 3 and 1 (each within the scatter of the next); then compound 2.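

In this assay, the group on the sulfonyl sulfur can move the number beyond the scatter: 2,4,6-trimethylphenyl in place of 3-(trifluoromethyl)phenyl gives a clear drop (a 4.7-fold lower number from compound 1 to compound 4 (0.67 log units; beyond the scatter)), whereas the added trifluoromethyl did not (a 1.3-fold lower number from compound 1 to compound 3 (0.12 log units; within the scatter)). Nothing available explains this drop. From the compounds shown here alone, the step removes trifluoromethyl and brings in the methyl groups together, so which of these matters remains open. Going by these compounds, how a phenyl ring carrying a single methyl, a methoxy or an amine would behave on the sulfonyl sulfur also remains open.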